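Expected Toxicity of Compound 4 After Removing Chlorine

The source may report more compounds than this note shows. Statements on the series, on what has been measured and on what is new or still open speak of the compounds shown alone.

Compound 1 `C=CCNC(=O)/C(C)=C(/C)c1ccc(Cl)cc1` and compound 2 `C=CCNC(=O)/C(C)=C(/C)c1ccccc1` share one core and differ by a single change, (hydrogen in place of chloro on an aromatic carbon). In a toxicity assay on the whole organism (strain Icem-CET (SPF Caw)) for cytotoxicity, with Mus musculus as the target (a higher number here means that more compound is needed for the effect, a lower number that less compound is needed), compound 1 gives 180 mg/kg, while compound 2 gives 550 mg/kg, so the step was a 3.1-fold higher number from compound 1 to compound 2 (0.49 log units; beyond the scatter). Compound 3 `C#CCNC(=O)/C(C)=C(\C)c1ccc(Cl)cc1` rests on a different core, and the difference between the two cores is not broken down here. In this assay compound 3 gives 60 mg/kg, the lowest of the three measured numbers. Compound 4 `C#CCNC(=O)/C(C)=C(\C)c1ccccc1` arises from compound 3 through the same change, (hydrogen in place of chloro on an aromatic carbon). Because the earlier step was a 3.1-fold higher number from compound 1 to compound 2 (0.49 log units; beyond the scatter), a step of about the same size is expected here, a 3.0-fold higher number from compound 3 to compound 4 (0.48 log units; beyond the scatter). Compound 4 is therefore estimated at 180 mg/kg in this assay, with a likely range from 90 mg/kg to 360 mg/kg.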

Compound 4, dose for half-maximal effect: 150 mg/kg
Beside the measured number, compound 4's estimate is 1.2-fold (0.08 log units) above it; the range from low to high includes it.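

Replacing the chloro with hydrogen gave a 2.5-fold higher number from compound 3 to compound 4 (0.40 log units; beyond the scatter) in this assay. The same change therefore carried over from one core to the other, in the same direction and with about the same size: the same change on two cores in this assay, a 3.1-fold higher number (0.49 log units; beyond the scatter) from compound 1 to compound 2 and a 2.5-fold higher number (0.40 log units; beyond the scatter) from compound 3 to compound 4, 1.2-fold (0.09 log units) apart, within the scatter of two such steps. Still, two matched pairs in a single assay do not explain why the number rises, nor do they show that the step would hold on a further core.

From the compounds shown here alone, only chloro and hydrogen appear at this place on the ring, so the effect of a fluoro, a methoxy or an amine there remains open. Going by these compounds, the effect of a longer chain on the amide nitrogen also remains open.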